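Isoflavone series: hexyloxy to 1-carboxyethoxy on the shared core

The compounds below may be only part of what the source reports. "The series", "measured", "known", "first", "only" and "open" are said of these compounds alone.

Measured so far:
compound 1 `CCOC(=O)CCCCOc1ccc2c(=O)c(-c3ccc(O)cc3)coc2c1` — 240 nM
compound 2 `CCCCCCOc1ccc2c(=O)c(-c3ccc(O)cc3)coc2c1` — 1500 nM

In an assay (Cricetulus griseus) for inhibition of aldehyde dehydrogenase, mitochondrial (Homo sapiens) (on this read-out higher numbers stand for weaker inhibition and lower numbers for stronger inhibition), compound 2 gives the highest of the two numbers; the nearest is compound 1, whose value sits a good way lower, and the step of a 6.3-fold higher number from compound 1 to compound 2 (0.80 log units; beyond the scatter) lies beyond the scatter. Compound 3 `CC(Oc1ccc2c(=O)c(-c3ccc(O)cc3)coc2c1)C(=O)O` is not yet measured. It differs from compound 2 as follows: 1-carboxyethyl in place of hexyl on an oxygen on an aromatic ring. Among the measured compounds shown here, only one measured step bears on this change, a 6.3-fold higher number from compound 1 to compound 2 (0.80 log units; beyond the scatter), which shows that a chain with a polar terminus gives a lower number than a plain hexyl chain. Compound 3 carries a shorter chain and a carboxylic acid rather than an ester, so the transfer is loose. A move to lower numbers is expected for compound 3, of roughly the size a 3.8-fold lower number from compound 2 to compound 3 (0.57 log units; beyond the scatter). Compound 3 is estimated at 400 nM, with a range from 100 nM to 1600 nM.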

Compound 3, half-maximal inhibitory concentration: 2500 nM
Compound 3: the middle estimate sits 6.3-fold (0.80 log units) below what was measured; the measured number lies above the stated range.
By their numbers in this assay, from the lowest: compound 1; then compounds 2 and 3 (each within the scatter of the next).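

In this assay, 1-carboxyethyl in place of hexyl on an oxygen on an aromatic ring gives a 1.7-fold higher number from compound 2 to compound 3 (0.22 log units; within the scatter) and so does not separate the two compounds. Against 4-(ethoxycarbonyl)butyl, the same group gives a 10-fold higher number from compound 1 to compound 3 (1.02 log units; beyond the scatter) and shows that an oxygen-bearing chain end alone does not go with the lower number of compound 1, since compound 3 also carries one and stays level with the plain hexyl of compound 2. Nothing available accounts for this result.

Between compound 1 and compound 3, chain length, branching and the end group all change at once, so no single one of these can be read alone. As far as these compounds go, a 4-carboxybutyl chain, the ethyl ester of 1-carboxyethyl and an amine at the chain end remain open as ways to separate these factors.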